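This account rests on a few compounds, and the source may have more. Where it says the series, first, only, none or still open, it means among the compounds named here.

Measured so far:
- Compound 1, `C=Cc1cn([C@H]2C[C@H](O)[C@@H](CO)O2)c(=O)[nH]c1=O`: 14200 nM
- Compound 2, `OC[C@H]1C[C@@H](Cn2cnc3c(NC4CC4)ncnc32)c2ccccc21`: > 200000 nM
- Compound 3, `C[C@@]1(CO)O[C@H](c2cc(F)c(N)cc2F)C[C@@H]1O`: > 200000 nM

In an ADME assay on L1210/0 cells (Mus musculus) for cytotoxicity, with a stated time of 48 h (a higher number here means a weaker inhibitor, a lower number a stronger inhibitor), compound 1 gives 14200 nM. For compound 2 the result in this assay is not a number but a limit of the assay, > 200000 nM. For compound 3 the result is likewise only a limit, > 200000 nM. Compound 1 therefore stands as the one compound with an actual number; the other two sit at the limit of > 200000 nM in this assay, at which 2 of the 3 values shown sit, so no measured step between any pair of these compounds can be drawn, and what the two limits show is only that those compounds were not caught by the assay.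

The compound that has not yet been measured is compound 4, `CC#Cc1cn([C@H]2C[C@H](O)[C@@H](CO)O2)c(=O)[nH]c1=O`. It differs from compound 1 in one place: prop-1-yn-1-yl in place of vinyl on an aromatic carbon. The shared core of compound 1 and the sugar attached to it are kept; only the small carbon chain on the aromatic carbon changes from a vinyl group to a prop-1-yn-1-yl group.

Within the data shown here, with no measured step on record, the expectation rests on the size of this change, which is modest. The step from compound 1 to compound 4 in this assay is expected to be small, within or close to the usual scatter, with a slight lean towards stronger inhibition, a 1.8-fold lower number from compound 1 to compound 4 (0.25 log units; within the scatter). Compound 4 is therefore estimated at 8000 nM, with a likely range from 1500 nM to 40000 nM.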

Compound 4, half-maximal inhibitory concentration: > 200000 nM
Compound 4 was reported as a limit; the forecaster's own chance of this, stated with the estimate: 5%; at least 25-fold (1.39 log units) between middle value and limit.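

Replacing vinyl with prop-1-yn-1-yl on this aromatic carbon, a swap of a 2-carbon group for a 3-carbon group, gives an at least 14-fold higher number from compound 1 to compound 4 (1.14 log units; beyond the scatter) in this assay. Among these compounds, the earlier compounds included no pair differing in one place, so only this pair shows that the measurable activity of compound 1 does not survive even this modest change at this position on the shared core. The result for compound 4 is a limit of the assay and not a number, and it places compound 4 with the other compounds that have no measured value: the limit of > 200000 nM in this assay, at which 3 of the 4 values shown sit.

From the compounds shown here alone, this single pair cannot separate the effect of the extra carbon from that of the triple bond in place of the double bond, and the distance between the limit for compound 4 and its true value remains unknown. Going by these compounds, an ethynyl group, which would keep the triple bond on a shorter chain, or a propyl chain, which would keep the longer chain without it, could begin to separate the two, and whether either would retain the activity of compound 1 remains open.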